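This account rests on a few compounds, and the source may have more. Where it says the series, first, only, none or still open, it means among the compounds named here.

Compounds that carry the same sulfonyl-linked oxazoline arm give quite different readings in a functional assay, tested at 100 ug/mL; on this read-out higher numbers stand for a stronger effect at the one concentration tested and lower numbers for a weaker effect. Compound 1 `COc1ccc(C2=NN(c3ccccc3)C(c3ccc(C)cc3)C2S(=O)(=O)CC2=NCCO2)cc1` reaches 67.7%, and compound 2 `O=S(=O)(CC1=NCCO1)c1c(-c2ccccc2)nn(-c2ccccc2)c1-c1ccccc1` gives 59.1%; these two readings lie within the usual scatter of each other. Compound 3 `O=S(=O)(CC1=NCCO1)c1n[nH]cc1-c1ccc(Cl)cc1`, a smaller member with fewer aryl groups, stands apart: in this assay compound 3 is reported as "not active" (no number reported), so no single number marks its place. Compound 4 `O=S(=O)(CC1=NCCO1)c1n[nH]cc1-c1ccccc1` differs from compound 3 only by hydrogen in place of chloro on an aromatic carbon. Among the compounds with values here, no measured pair shows that change here, so the step from compound 3 to compound 4 in this assay is expected to stay small, in no clear direction, and within the scatter. Compound 4 is therefore estimated at 15%, between 0% and 40%.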

Compound 4, a percentage reported as activity, at one concentration (the size of the read-out at that concentration, not a potency): 58.5%
Compound 4: middle estimate off by 43.5 percentage points, on the low side; measured number above the stated range.
By their numbers in this assay, from the lowest: compounds 4, 2 and 1 (each within the scatter of the next).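

Within the data shown here, compound 3 has no number in this assay and so no step to compound 4 at 58.5% can be read. The compounds shown leave open how large the change from 4-chlorophenyl to phenyl is on this read-out. No measurement shown accounts for the result.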